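This account rests on a few compounds, and the source may have more. Where it says the series, first, only, none or still open, it means among the compounds named here.

Compound 1, `COc1ccc(CNCc2c(OC)cc(Oc3cccc(Nc4ccccc4)c3)cc2OC)cc1`, stands at the highest of the two numbers in a functional assay on SW-620 cells (Homo sapiens) for inhibition, read by MTT assay, with a stated time of 72 h; on this read-out lower numbers stand for stronger inhibition and higher numbers for weaker inhibition: in this assay compound 1 gives 6970 nM. Its nearest neighbour is compound 2, `COc1ccc(CCCNCc2c(OC)cc(Oc3cccc(Nc4ccccc4)c3)cc2OC)cc1`, which in this assay gives 6400 nM, so that the change a 1.1-fold lower number from compound 1 to compound 2 (0.04 log units; within the scatter) shows no effect beyond the scatter. The new compound 3, `COc1cc(Oc2cccc(Nc3ccccc3)c2)cc(OC)c1CNC(C)C`, differs from compound 1 by isopropyl in place of 4-methoxybenzyl on an amine nitrogen. Within the data shown here, the single measured step concerns only a longer or shorter link between the amine nitrogen and the 4-methoxyphenyl group, and it bears only loosely on a change that removes the aromatic ring altogether. Among the measured compounds shown here, no measured step speaks to this replacement directly. Given the flat result of a 1.1-fold lower number from compound 1 to compound 2 (0.04 log units; within the scatter), compound 3 is expected to give a number of similar size, with an expected step of a 1.2-fold higher number from compound 1 to compound 3 (0.09 log units; within the scatter) within or near the scatter. The estimate for compound 3 is 8500 nM, with a range from 3000 nM to 25000 nM.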

Compound 3, half-maximal inhibitory concentration: > 20000 nM
Compound 3 was reported as a limit; the forecaster's own chance of this, stated with the estimate: 10%; middle value at least 2.3-fold (0.37 log units) away from the limit.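

In this assay the result for compound 3 is a limit and not a number: the limit of > 20000 nM in this assay, at which 1 of the 3 values shown sits. Putting isopropyl on the amine nitrogen moves the read-out beyond the scatter, with an at least 2.8-fold higher number from compound 1 to compound 3 (0.45 log units; beyond the scatter) and an at least 3.1-fold higher number from compound 2 to compound 3 (0.49 log units; beyond the scatter), whereas the step between the two compounds carrying the 4-methoxyphenyl group stayed within it. This position is therefore not indifferent to every change: among the three compounds, the link to the 4-methoxyphenyl group varies with no effect beyond the scatter, while replacing the whole group with isopropyl goes with weaker inhibition.

The compounds shown leave open whether the aromatic ring, the methoxy oxygen or the number of heavy atoms is what counts. An unsubstituted benzyl, a cyclohexylmethyl or a longer straight alkyl chain on the amine nitrogen would begin to separate these.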